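Swapping 4-chlorophenyl for 3-methoxyphenyl on a shared core

The compounds below may be only part of what the source reports. "The series", "measured", "known", "first", "only" and "open" are said of these compounds alone.

In a physicochemical assay for solubility, read by nephelometry, measured as kinetic solubility, at pH 2.0 (a lower number here means a less soluble compound, a higher number a more soluble compound), compound 1 (`CCOC(=O)C1=C(O)/C(=C\c2cc(C)n(-c3ccc(F)cc3)c2C)N=C1C`) gives 6.3 ug/mL and compound 3 (`CCOC(=O)C1=C(C)N/C(=C/c2cc(C)n(-c3cc(OC)c(OC)c(OO)c3)c2C)C1=O`) gives 6.3 ug/mL as well. Compound 2 (`CCOC(=O)C1=C(C)N/C(=C/c2cc(C)n(-c3ccc(Cl)cc3)c2C)C1=O`) stands lowest of the three at 1.6 ug/mL and its gap to each of the other two lies beyond the scatter, the spread that repeat measurements of the same compound would show.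

Within the data shown here, compound 4 (`CCOC(=O)C1=C(C)N/C(=C/c2cc(C)n(-c3cccc(OC)c3)c2C)C1=O`) has no measurement yet. It carries 3-methoxyphenyl in place of 4-chlorophenyl on an aromatic nitrogen and otherwise matches compound 2.

Among the measured compounds shown here, no two measured compounds differ in one place only, so the data hold no direct example of what a swap like this does. For the measured compounds named here, the only guide is the range of the values, which run from compound 2 at 1.6 ug/mL to compound 3 at 6.3 ug/mL and no further. Compound 2 already sits at the bottom of that range, so a rise of similar or smaller size is the more likely outcome in this assay and a large move in either direction is not expected. The estimated change is a 2.5-fold higher number from compound 2 to compound 4 (0.40 log units; beyond the scatter) and it may turn out to be close to the scatter. For compound 4 the estimated value is 4 ug/mL (expected range 1.6 ug/mL to 12 ug/mL).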

Compound 4, solubility: 6.3 ug/mL
For compound 4 the middle estimate is 1.6-fold (0.20 log units) below the measured one; measured number inside the range.
By their numbers in this assay, from the lowest: compound 2; then compounds 1, 3 and 4 (each within the scatter of the next).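

Among these compounds, this is the first pair that differs in one place only, so the group on the aromatic nitrogen can now be read directly. In this assay, 3-methoxyphenyl in place of 4-chlorophenyl gives a 3.9-fold higher number from compound 2 to compound 4 (0.60 log units; beyond the scatter), showing that a change confined to this nitrogen substituent, with the rest of the structure held the same, is enough to move the number beyond the scatter. No measurement on hand accounts for this step.

One swap removes the chlorine, adds a methoxy group and changes where the substituent sits on the phenyl ring, so this pair cannot show which of those differences goes with the higher number. Plain phenyl and 4-methoxyphenyl would help separate those differences, while a phenyl ring carrying an amine or a carboxylic acid would show how this position responds to quite different groups.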